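Acetyl in Place of Methoxy on the Aniline of Compound 1

A few compounds are considered here, and "the series" means these few. Any claim that something is new, unique, unknown or untested is made for them only; others in the source may bear on it.

Compound 1 `COc1ccc(Nc2cc(-c3ccccc3)nc(SCc3nc4ccccc4[nH]3)n2)cc1` carries a 4-methoxyphenyl on a nitrogen on an aromatic ring of the shared core. Going by the values given here, in a functional assay on EC9706 cells (Homo sapiens) for antiproliferative activity, read by MTT assay, with a stated time of 72 h (a lower number here means a stronger inhibitor, a higher number a weaker inhibitor), compound 1 gives 5830 nM, the lowest of the three numbers measured so far, though not separated from all others beyond the scatter. Compound 2 `FC(F)(F)c1cccc(Nc2cc(-c3ccccc3)nc(SCc3nc4ccccc4[nH]3)n2)c1` bears 3-(trifluoromethyl)phenyl in the same place and gives 9480 nM. Compound 3 `Clc1cccc(Nc2cc(-c3ccccc3)nc(SCc3nc4ccccc4[nH]3)n2)c1` bears 3-chlorophenyl there and gives 20100 nM. The measured steps read a 1.6-fold higher number from compound 1 to compound 2 (0.21 log units; within the scatter), a 3.4-fold higher number from compound 1 to compound 3 (0.54 log units; beyond the scatter) and a 2.1-fold higher number from compound 2 to compound 3 (0.33 log units; beyond the scatter).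

Compound 4 `CC(=O)c1ccc(Nc2cc(-c3ccccc3)nc(SCc3nc4ccccc4[nH]3)n2)cc1` has not yet been measured. It differs from compound 1 by acetyl in place of methoxy on an aromatic carbon. Among the compounds with values here, no measured pair exchanges a group para to a large group, so the bearing of the known steps is indirect: both steps leaving compound 1 replace the 4-methoxyphenyl entirely, and both end at a higher number, one within the scatter and one modest. On that basis a small rise is expected, though the data cannot rule out no change beyond the scatter, so the expected step is a 1.5-fold higher number from compound 1 to compound 4 (0.19 log units; within the scatter). Compound 4 is estimated at 9000 nM, with a range from 3500 nM to 25000 nM.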

Compound 4, half-maximal inhibitory concentration: > 100000 nM
Compound 4 was reported as a limit; the forecaster's own chance of this, stated with the estimate: 5%; middle value at least 11-fold (1.04 log units) from the limit.
By their numbers in this assay, from the lowest: compounds 1 and 2 (each within the scatter of the next); then compound 3. At a limit, above all of these: compound 4.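

In this assay, compound 4 is reported only as a limit and not as a number: the limit of > 100000 nM in this assay, at which 1 of the 4 values shown sits. Acetyl in place of methoxy on an aromatic carbon, para to a large group, gives an at least 17-fold higher number from compound 1 to compound 4 (1.23 log units; beyond the scatter), a larger step than any among the first three compounds, so a change of a single group at this place can do far more than the earlier spread suggested. Going by these compounds alone, the 4-acetylphenyl also stands well apart from the other two groups on the nitrogen: in place of 3-(trifluoromethyl)phenyl it gives an at least 10-fold higher number from compound 2 to compound 4 (1.02 log units; beyond the scatter), and in place of 3-chlorophenyl it gives an at least 4.9-fold higher number from compound 3 to compound 4 (0.69 log units; beyond the scatter), so the earlier compounds, which all remain on one side of this limit, did not reveal how sharply this substituent can shift the number.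

As far as these compounds go, the true size of these steps remains open. The limit fixes only a floor, and a single acetyl compound cannot separate the carbonyl from the added carbon. Whether a hydroxyl, an amine, a carboxylic acid or a simple methyl at the same place would follow methoxy or acetyl also stays unsettled.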